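A few compounds are considered here, and "the series" means these few. Any claim that something is new, unique, unknown or untested is made for them only; others in the source may bear on it.

In a functional assay on MOLT-4 cells (Homo sapiens) for inhibition, read by MTT assay, with a stated time of 4 days (on this read-out higher numbers stand for weaker inhibition and lower numbers for stronger inhibition), compound 1 `COc1cc(NC(C)CCCNC(=O)NNC(=O)NCCCCCO)c2ncccc2c1` gives >= 250000 nM as its reading, which is a limit of the assay and not a number. Compound 2 `CCOC(=O)NC(c1ccccc1)c1ccc(Cl)cc1` gives > 250000 nM as its reading, and this too is a limit. Going by the values given here, a different substituent on the core of compound 1 appears in compound 3 `COc1cc(NC(C)CCCNC(=O)NNC(=O)N(C)C(c2ccccc2)c2ccccc2)c2ncccc2c1`, which gives 19000 nM as the only true number of the three. Compound 1 therefore offers no exact starting value, only its place at the limit.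

Compound 4 `COc1cc(NC(C)CCCNC(=O)NNC(=O)NC(CO)(CO)CO)c2ncccc2c1` keeps the core of compound 1 and changes one group, with 2-hydroxy-1,1-bis(hydroxymethyl)ethyl in place of 5-hydroxypentyl on an amide-type nitrogen. The change counts out as 2-hydroxy-1,1-bis(hydroxymethyl)ethyl in place of 5-hydroxypentyl on an amide-type nitrogen and touches nothing else.

In this assay, among the compounds with values here, no measured step shows what such a swap does. The expected step of a number no higher from compound 1 to compound 4 (the limit leaves the size open) is none beyond the usual scatter, in either direction. Within the data shown here, this expectation rests on compound 1 and its limit of >= 250000 nM as the only reading for the group being replaced. Compound 4 is estimated at 250000 nM with an expected range from 120000 nM to 400000 nM and may well sit at a limit again.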

Compound 4, half-maximal inhibitory concentration: > 250000 nM
Compound 4: no number, only a limit; the forecaster's own chance of this, stated with the estimate: 75%; the middle value lies on the limit itself.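

In this assay compound 4 gives > 250000 nM, a limit of the assay and not a number. Compound 1 gives >= 250000 nM, which is also a limit. Going by these compounds alone, with both readings at limits, no step between compound 1 and compound 4 can be read. The compounds shown leave open whether 2-hydroxy-1,1-bis(hydroxymethyl)ethyl in place of 5-hydroxypentyl changes inhibition at all.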